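This account rests on a few compounds, and the source may have more. Where it says the series, first, only, none or still open, it means among the compounds named here.

Measured in a toxicity assay on L3.6pl cells (Homo sapiens) for inhibition, read by ATP content, with a stated time of 72 h; on this read-out higher numbers stand for weaker inhibition and lower numbers for stronger inhibition:
- Compound 1 `COc1ccccc1C(=O)Nc1ccc(N2CCN(c3cc(Cl)ccc3C)CC2)cc1C(=O)O`: 29100 nM
- Compound 2 `COc1ccccc1C(=O)Nc1ccc(N2CCN(CCCc3ccccc3)CC2)cc1C(=O)O`: > 10000 nM

Compound 2 gives only a limit, > 10000 nM, and not a number. Compound 3 `COc1ccccc1C(=O)Nc1ccc(N2CCN(Cc3ccccn3)CC2)cc1C(=O)O` differs from it by pyridin-2-yl in place of phenethyl on a saturated chain carbon bound to an amine nitrogen in a ring. Among the compounds with values here, the one measured step is a step that the limit leaves unreadable from compound 1 to compound 2, so it gives no size or direction to carry over. Within the data shown here, the only number to lean on is that of compound 1, 29100 nM. The expected change in this assay is a step that the limit leaves unreadable from compound 2 to compound 3, with no direction foreseen. Compound 3 is expected near 25000 nM, with an estimated range of 10000 nM to 60000 nM.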

Compound 3, half-maximal inhibitory concentration: > 100000 nM
Compound 3 gave a limit, no number; the forecaster's own chance of this, stated with the estimate: 55%; at least 4.0-fold (0.60 log units) between middle value and limit.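

In this assay compound 3 gives only a limit, > 100000 nM, and not a number. Even so, (pyridin-2-yl)methyl in place of 5-chloro-2-methylphenyl on this amine nitrogen gives an at least 3.4-fold higher number from compound 1 to compound 3 (0.53 log units; beyond the scatter), so the group here can shift the read-out toward weaker inhibition beyond the scatter. The steps involving compound 2 to compound 3 cannot be read, as both values are limits.

On these data alone, whether the pyridine nitrogen itself matters stays open, since 3-phenylpropyl and (pyridin-2-yl)methyl cannot be ranked. A plain benzyl group on the same amine nitrogen would test this directly.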